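The source may hold more compounds than are shown below. What is called first, only, known or untested is meant among the compounds shown, and "the series" means these compounds.

Measured so far in a functional assay on MDA-MB-231 cells (Homo sapiens) for inhibition, read by sulforhodamine B assay, tested at 10 uM; on this read-out lower numbers stand for less inhibition and higher numbers for more inhibition at the one concentration tested (going by the name of the read-out):
compound 1 `CN1CCN(c2ccc(C3=NN(S(=O)(=O)C4CC4)C(c4ccc(N(C)C)cc4)C3)cc2)CC1`: 3.7%
compound 2 `Cc1ccc(S(=O)(=O)N2N=C(c3ccc(N4CCN(C)CC4)cc3)CC2c2ccc(N(C)C)cc2)cc1`: 10.7%

Going by the values given here, compound 2 holds the upper of the two numbers, but the one step available, a number 7 percentage points higher from compound 1 to compound 2 (within the scatter), keeps both within the scatter, so no order between them is established. Compound 3 `CN1CCN(c2ccc(C3=NN(S(=O)(=O)c4ccc(Br)cc4)C(c4ccc(N(C)C)cc4)C3)cc2)CC1` differs from compound 2 by bromo in place of methyl on an aromatic carbon. Among the compounds with values here, no measured step changes this place; the single known step, at the sulfonyl sulfur, gave nothing beyond the scatter. For compound 3 the expected step is therefore none beyond the scatter, a number 1.3 percentage points higher from compound 2 to compound 3 (within the scatter). Compound 3 is estimated at 12%, with a range of 0% to 30%.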

Compound 3, a percentage reported as inhibition, at one concentration (the size of the read-out at that concentration, not a potency): 23.7%
Compound 3: the middle estimate sits 11.7 percentage points below what was measured; the range from low to high includes it.
By their numbers in this assay, from the lowest: compounds 1 and 2 (each within the scatter of the next); then compound 3.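

In this assay, going by these compounds alone, the substituent on the phenyl ring of the sulfonyl group is the first change to move the number beyond the scatter, with bromo in place of methyl giving a number 13 percentage points higher from compound 2 to compound 3 (beyond the scatter) at this place. Replacing cyclopropyl with 4-bromophenyl on the sulfonyl sulfur gives a number 20 percentage points higher from compound 1 to compound 3 (beyond the scatter), whereas 4-methylphenyl there stayed within the scatter of cyclopropyl. Nothing shown explains the difference between bromo and methyl.

As far as these compounds go, whether chloro, methoxy or an amine at this place would follow bromo remains open. So does whether any such step would hold with other groups on the shared core.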